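Series notes: chloro added to compound 2

The source may report more compounds than this note shows. Statements on the series, on what has been measured and on what is new or still open speak of the compounds shown alone.

Compound 1 `CNc1nc(NCCCN(C)C)c2sc(-c3ccc(S(C)(=O)=O)cc3)cc2n1` gives 2.1 in a physicochemical assay for lipophilicity, read by HPLC, at pH 7.4; a higher number here means a more lipophilic compound, a lower number a more polar compound. Among the measured compounds shown here, compound 2 `CNc1nc(NCCCN(C)C)c2sc(-c3ccc(C(F)(F)F)cc3)cc2n1` gives 4.1 in this assay; of the two numbers it stands highest, with compound 1 the nearest, and the step of a number 2.00 log units higher from compound 1 to compound 2 (beyond the scatter) is the only measured step. Compound 3 `CNc1nc(NCCCN(C)C)c2sc(-c3ccc(C(F)(F)F)cc3Cl)cc2n1` has not yet been measured in this assay. It differs from compound 2 by chloro in place of hydrogen on an aromatic carbon. For the measured compounds named here, no measured step matches this change: the single step of a number 2.00 log units higher from compound 1 to compound 2 (beyond the scatter) exchanges one whole group for another and shows only how wide the spread already is. Going by the values given here, the expected step in this assay is a number 0.60 log units higher from compound 2 to compound 3 (beyond the scatter), upward and probably just beyond the scatter, though with no direct precedent the expectation is loose. Compound 3 is expected to give 4.7 in this assay, with a range from 4.2 to 5.3.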

Compound 3, distribution coefficient: 4.5
Compound 3: middle estimate off by 0.20 log units, on the high side, and the stated range covers the measured number.
By their numbers in this assay, from the lowest: compound 1; then compound 2; then compound 3.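

In this assay, a change of a single atom gives a number 0.40 log units higher from compound 2 to compound 3 (beyond the scatter), which shows that this position, ortho to a large group and meta to a trifluoromethyl group, responds to chloro in place of hydrogen by more than the scatter. Among the compounds shown here, the only earlier step exchanged one whole group for another; here the trifluoromethyl group stays and 1 heavy atom enters, and the resulting step is modest beside a number 2.00 log units higher from compound 1 to compound 2 (beyond the scatter). Nothing available here bears on why the step has this size.

Going by these compounds, whether chloro would give a similar step on compound 1, which carries methylsulfonyl in place of trifluoromethyl, remains open. Also open, on these data alone, is how other groups at this same position, such as fluoro, methoxy or an amine, would compare with chloro.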